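From acetoxy to methoxy on a shared core

The compounds below may be only part of what the source reports. "The series", "measured", "known", "first", "only" and "open" are said of these compounds alone.

Of the compounds shown here, two have so far been measured in a functional assay on DU-145 cells (Homo sapiens) for cytotoxicity, read by XTT assay, with a stated time of 24 h (a lower number here means a stronger inhibitor, a higher number a weaker inhibitor), and both give high numbers. Compound 1 `COc1c(C)cc(Cl)c2c1C(=O)C=CC2=O` gives 36500 nM and compound 2 `CC(=O)Oc1cc(C)c(Cl)c2c1C(=O)C=CC2=O` gives 25500 nM in the same test. These two values lie within the scatter of each other, so compound 2 stands level with compound 1 and the pair cannot be ranked.

Compound 3 `COc1cc(C)c(Cl)c2c1C(=O)C=CC2=O` has not yet been measured. It differs from compound 2 by methyl in place of acetyl on an oxygen on an aromatic ring, which is acetoxy to methoxy, and the counted change reads methyl in place of acetyl on an oxygen on an aromatic ring in full.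

Going by the values given here, no step between measured compounds bears directly on this change. Compound 1 also carries a methoxy group, and with compound 1 at 36500 nM as the only measured reference of that kind, no shift beyond the scatter is expected in this assay and no firm direction either. The estimated move is a 1.2-fold higher number from compound 2 to compound 3 (0.07 log units; within the scatter) and it is expected to stay within the scatter. Compound 3 is expected at 30000 nM with 12000 nM to 70000 nM as the estimated range.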

Compound 3, half-maximal inhibitory concentration: 26600 nM
For compound 3 the middle estimate is 1.1-fold (0.05 log units) above the measured one, within the range that was stated.
By their numbers in this assay, from the lowest: compounds 2, 3 and 1 (each within the scatter of the next).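

In this assay, going by these compounds alone, the exchange of acetoxy for methoxy gives the first step between compounds that differ in one place, and a 1.0-fold higher number from compound 2 to compound 3 (0.02 log units; within the scatter) it stays inside the scatter. Before this step, nothing could be said about the oxygen on an aromatic ring on its own; now it is seen that acetyl can leave, taking its double bond outside aromatic rings and its hydrogen-bond acceptor with it, and methyl can enter without a difference that can be told from repeat measurement, at least on this shared core and in this test. No measured information in hand accounts for this result, so the level values stand as an observation without an explanation.

The compounds shown leave open whether anything on this oxygen can move the number beyond the scatter, for instance a longer chain, a carboxylic acid at the end of such a chain, or an amine-bearing chain, or whether a free hydroxyl group would do so. They also leave open whether the same exchange would stay level on a core carrying its chloro and methyl groups differently.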